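Replacing a Fluoro-Benzyl Arm with a Nitro-Benzyl Arm

The compounds below may be only part of what the source reports. "The series", "measured", "known", "first", "only" and "open" are said of these compounds alone.

Compound 1 `O=C(C1CCCN(Cc2ccccc2)C1)N1CCN(c2ccccc2Cl)CC1`: 86%
Compound 2 `O=C(C1CCCN(Cc2ccccc2F)C1)N1CCN(c2ccccc2Cl)CC1`: 74%

In a functional assay on a cell-free system (Platelet, plasma, Homo sapiens), with stated times of 4 min and 5.5 min, tested at 0.1 uM (on this read-out higher numbers stand for a weaker effect at the one concentration tested and lower numbers for a stronger effect), compound 1 gives 86% and compound 2 gives 74%. Going by the values given here, compound 2 therefore stands lowest of the two numbers, with compound 1 as its only neighbour. Compound 3 `O=C(C1CCCN(Cc2ccc([N+](=O)[O-])cc2)C1)N1CCN(c2ccccc2Cl)CC1` differs from compound 2 by 4-nitrophenyl in place of 2-fluorophenyl on a saturated chain carbon bound to an amine nitrogen in a ring. Among the compounds with values here, the single measured step, a number 12 percentage points lower from compound 1 to compound 2 (beyond the scatter), changed the same benzyl ring and bears on this step only loosely, since a different group enters at a different place. A modest step is expected, estimated as a number 4 percentage points lower from compound 2 to compound 3 (within the scatter), possibly within the scatter. Compound 3 is estimated at 70%, between 45% and 90%.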

Compound 3, a percentage reported as activity, at one concentration (the size of the read-out at that concentration, not a potency): 57%
For compound 3 the middle estimate is 13 percentage points above the measured one; low and high end bracket the measured number.
By their numbers in this assay, from the lowest: compound 3; then compound 2; then compound 1.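

In this assay the swap of 2-fluorobenzyl for 4-nitrobenzyl gives a number 17 percentage points lower from compound 2 to compound 3 (beyond the scatter) and nitro in place of hydrogen on the benzyl ring gives a number 29 percentage points lower from compound 1 to compound 3 (beyond the scatter) on the same scale. The benzyl arm therefore responds to more than fluoro, and compound 3 now holds the lowest number, meaning the strongest effect of the three at the one concentration tested. Nothing measured here accounts for this shift.

Going by these compounds, whether the result depends on where the nitro group sits on the ring remains open. So does whether an amine or a carboxylic acid on that ring would push the number lower still.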